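From 4-methoxyphenyl to pentan-3-yl in compound 4

A few compounds are considered here, and "the series" means these few. Any claim that something is new, unique, unknown or untested is made for them only; others in the source may bear on it.

Compound 1 `COc1cc(N)c(Cl)cc1NC(=O)C1CCN(Cc2ccccc2Cl)CC1` gives > 4 mg/kg in a functional assay on the whole organism for antagonist activity, with Mus musculus as the target (on this read-out lower numbers stand for an effect already at smaller amounts and higher numbers for an effect only at larger amounts of compound), which is a limit of the assay rather than a number.
Compound 2 `COc1cc(N)c(Cl)cc1NC(=O)C1CCN(Cc2cccc(C#N)c2)CC1` gives > 4 mg/kg in this assay, again a limit.
Compound 3 `COc1ccc(CN2CCC(C(=O)Nc3cc(Cl)c(N)cc3OC)CC2)cc1` gives 0.9 mg/kg in this assay.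

Compound 3 thus holds the only number shown; the other two values sit at the limit of > 4 mg/kg in this assay, at which 2 of the 3 values shown sit. The untested compound 4 `CCC(CC)CN1CCC(C(=O)Nc2cc(Cl)c(N)cc2OC)CC1` differs from compound 3 by pentan-3-yl in place of 4-methoxyphenyl on a saturated chain carbon bound to an amine nitrogen in a ring. Going by the values given here, two measured steps bear on this change: an at least 4.4-fold lower number from compound 1 to compound 3 (0.64 log units; beyond the scatter) and an at least 4.4-fold lower number from compound 2 to compound 3 (0.64 log units; beyond the scatter), both showing the 4-methoxyphenyl compound with the lower number. Compound 4 lacks that group altogether, so a step back towards higher numbers is expected: a 5.6-fold higher number from compound 3 to compound 4 (0.74 log units; beyond the scatter). Compound 4 is estimated at 5 mg/kg, with a range from 1.5 mg/kg to 20 mg/kg, and a fair chance that only a limit is reported.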

Compound 4, dose for half-maximal effect: > 10 mg/kg
Compound 4 gave a limit, no number; the forecaster's own chance of this, stated with the estimate: 60%; middle value at least 2.0-fold (0.30 log units) from the limit.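

Pentan-3-yl in place of 4-methoxyphenyl gives an at least 11-fold higher number from compound 3 to compound 4 (1.04 log units; beyond the scatter) in this assay, which leaves compound 3 as the only compound shown with a measured number. The earlier compounds shown here set 4-methoxyphenyl against two other substituted phenyl groups; this result adds that a group with no ring, on a saturated chain carbon bound to an amine nitrogen in a ring, does not bring the number down either. The values of compound 1, compound 2 and compound 4 are all limits, and the steps among them cannot be read.

From the compounds shown here alone, it remains open whether the methoxy group itself matters, which an unsubstituted phenyl, a 4-hydroxyphenyl or a 3-methoxyphenyl at this place could show.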